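The source may hold more compounds than are shown below. What is called first, only, known or untested is meant among the compounds shown, and "the series" means these compounds.

Measured so far in a functional assay on HUVEC cells (Homo sapiens), read by BrdU incorporation, with a stated time of 72 h; a higher number here means a weaker inhibitor, a lower number a stronger inhibitor:
- compound 1 `Cc1ccc2nc(Cl)c(/C=C/C(=O)c3sccc3Cl)cc2c1` gives 37.5 nM
- compound 2 `Cc1ccc2nc(Cl)c(/C=C/C(=O)c3cc(Cl)sc3Cl)cc2c1` gives 26.2 nM

Compound 2 stands level with compound 1, as the two values lie within the usual scatter of each other. Compound 3 `Cc1ccc2nc(Cl)c(/C=C/C(=O)c3ccc(Br)s3)cc2c1` has not yet been measured. It differs from compound 2 in one place: 5-bromothiophen-2-yl in place of 2,5-dichlorothiophen-3-yl on a carbonyl carbon. For the measured compounds named here, the single measured step at this carbonyl carbon is a 1.4-fold lower number from compound 1 to compound 2 (0.16 log units; within the scatter), seen with 2,5-dichlorothiophen-3-yl in place of 3-chlorothiophen-2-yl. Going by the values given here, that small step is the only guide, and a thin one, so no step beyond the scatter is expected in this assay here. The estimated change is a 1.1-fold higher number from compound 2 to compound 3 (0.06 log units; within the scatter) in size. For compound 3 the expected value is 30 nM, with a likely range from 12 nM to 80 nM as a first guess.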

Compound 3, half-maximal inhibitory concentration: 88.4 nM
The estimate for compound 3 lay 2.9-fold (0.47 log units) below the measured number; measured number outside the range, above it.
By their numbers in this assay, from the lowest: compounds 2 and 1 (each within the scatter of the next); then compound 3.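

In this assay, the group on the carbonyl carbon proves able to shift the number beyond the scatter: 5-bromothiophen-2-yl gives a 3.4-fold higher number from compound 2 to compound 3 (0.53 log units; beyond the scatter), and in place of 3-chlorothiophen-2-yl it gives a 2.4-fold higher number from compound 1 to compound 3 (0.37 log units; beyond the scatter). The earlier step stayed within the scatter, so it could have suggested that one halogen-bearing thiophene serves as well as another, but these compounds show that this does not hold for every such exchange. No supporting measurement is available to explain the shift.

The names 5-bromothiophen-2-yl and 3-chlorothiophen-2-yl differ in both the halogen and its numbered place on the ring, so these compounds cannot show which of the two matters. Going by these compounds, how a thiophene bearing an amine or a carboxylic acid instead of a halogen would read in this assay also remains open.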